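The source may hold more compounds than are shown below. What is called first, only, known or untested is meant among the compounds shown, and "the series" means these compounds.

Measured so far:
- compound 1, `CCCNC(=C\C(=O)/C=C/c1ccc(O)c(OC)c1)/C=C/c1ccc(O)c(OC)c1`: 141%
- compound 2, `CC(C)CNC(=C\C(=O)/C=C/c1ccc(O)cc1)/C=C/c1ccc(O)cc1`: 119%
- compound 3, `COc1cc(/C=C/C(=O)/C=C(/C=C/c2ccc(OC(C)=O)c(OC)c2)NCC(C)C)ccc1OC(C)=O`: 240%

In a functional assay on EA.hy 926 cells (Homo sapiens), read by fluorescence, tested at 10 uM (a lower number here means a weaker effect, a higher number a stronger effect of the compound at the concentration tested), compound 1 stands second highest of the three numbers; compound 2 gives a lower number and compound 3 a higher one, both gaps beyond the scatter. Compound 4, `COc1cc(/C=C/C(=O)/C=C(/C=C/c2ccc(O)c(OC)c2)NC2CCCCC2)ccc1O`, is not yet measured. It differs from compound 1 at a single place: cyclohexyl in place of propyl on an amine nitrogen. No measured pair differs only in the group on the amine nitrogen, so the weight of this change in this assay has no direct precedent among these compounds. A small step is expected, within or only just beyond the scatter, with no firm direction, so the step of a number 9 percentage points higher from compound 1 to compound 4 (within the scatter) is estimated as modest. Compound 4 is expected to give 150%, within the range 105% to 215%.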

Compound 4, a percentage reported as activity, at one concentration (the size of the read-out at that concentration, not a potency): 191%
The estimate for compound 4 lay 41 percentage points below the measured number; the range from low to high includes it.
By their numbers in this assay, from the lowest: compound 2; then compound 1; then compound 4; then compound 3.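

In this assay, going by these compounds alone, cyclohexyl in place of propyl on an amine nitrogen gives a number 50 percentage points higher from compound 1 to compound 4 (beyond the scatter) and provides the first direct reading of this position. The group on this nitrogen therefore matters at the concentration tested, with the rest of the core of compound 1 unchanged. Nothing at hand accounts for the rise.

Still open, as far as these compounds go, is whether a benzyl group or a longer chain such as hexyl on this nitrogen would move the number in the same direction. Also open, from the compounds shown here alone, is whether a smaller ring, such as cyclopropyl, retains the step.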